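An aryl swap on the amide of a weakly active series

This account rests on a few compounds, and the source may have more. Where it says the series, first, only, none or still open, it means among the compounds named here.

Compound 1 `O=C(Nc1ccc(Cl)c(-c2nnc3c(Cl)cccn23)c1)c1ccc(Cl)cc1`: in a functional assay on MDA-MB-231 cells (Homo sapiens) for antiproliferative activity, read by MTT assay, with stated times of 72 h and 4 h (on this read-out lower numbers stand for stronger inhibition and higher numbers for weaker inhibition), compound 1 reaches only the limit > 100000 nM.
Compound 2 `O=C(Nc1ccc(Cl)c(-c2nnc3c(Cl)cccn23)c1)c1cccc(Cl)c1`: in this assay compound 2 gives 66100 nM.
Compound 3 `CS(=O)(=O)c1ccc(C(=O)Nc2ccc(Cl)c(-c3nnc4c(Cl)cccn34)c2)cc1`: in this assay compound 3 reaches only the limit > 100000 nM.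

Compound 3 therefore stands at the limit of this assay, a limit shared by two of the three values shown (the limit of > 100000 nM in this assay, at which 2 of the 3 values shown sit). Compound 4 `O=C(Nc1ccc(Cl)c(-c2nnc3c(Cl)cccn23)c1)c1c(F)cccc1Cl` differs from compound 3 in one place: 2-chloro-6-fluorophenyl in place of 4-(methylsulfonyl)phenyl on a carbonyl carbon. The measured steps that bear on a change of the aryl group on the carbonyl carbon are an at least 1.5-fold lower number from compound 1 to compound 2 (0.17 log units; that floor lies within the scatter), a step that the two limits leave unreadable from compound 1 to compound 3 and an at least 1.5-fold higher number from compound 2 to compound 3 (0.17 log units; that floor lies within the scatter); none of them is readable beyond the scatter. Compound 4 is therefore expected to give a number near the limit, with no step beyond the scatter, and its value in this assay is estimated at 80000 nM, between 30000 nM and 200000 nM. That expectation amounts to a step of an at least 1.2-fold lower number from compound 3 to compound 4 (0.09 log units; that floor lies within the scatter).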

Compound 4, half-maximal inhibitory concentration: > 100000 nM
Compound 4: no number, only a limit; the forecaster's own chance of this, stated with the estimate: 50%; middle value at least 1.2-fold (0.09 log units) away from the limit.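

In this assay compound 4 gives > 100000 nM, which is a limit and not a number. A third aryl group on the carbonyl carbon, here 2-chloro-6-fluorophenyl, thus ends at the same limit as the 4-chlorophenyl and 4-(methylsulfonyl)phenyl groups: the limit of > 100000 nM in this assay, at which 3 of the 4 values shown sit. Of the new steps only one can be read, an at least 1.5-fold higher number from compound 2 to compound 4 (0.17 log units; that floor lies within the scatter); the other two cannot be read.

As far as these compounds go, it remains open whether an amine or a carboxylic acid on this aryl group would give a measurable number in this assay. The same holds for a longer alkyl chain in place of the aryl group.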